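The compounds below may be only part of what the source reports. "The series", "measured", "known", "first", "only" and "open" are said of these compounds alone.

Measured in an ADME assay on microsomes from liver (Homo sapiens) for metabolic stability, read by LC-MS, with a stated time of 10 min; a higher number here means that more of the compound is left, a lower number that less of the compound is left:
- compound 1 `Cc1cnc(CN(C)C[C@H]2Cc3c(cccc3N3CCNCC3)CN2)c(C)c1`: "not determined" (no result reported)
- compound 2 `CN(C[C@H]1Cc2c(cccc2N2CCNC(C)(C)C2)CN1)[C@H]1CCCc2cccnc21`: 100%

Among the measured compounds shown here, compound 2, at 100%, holds the only number, so it cannot yet be ranked against anything. Compound 1 offers no comparison.

Next in this assay is compound 3 `CN1CCN(c2cccc3c2C[C@H](CN(C)[C@H]2CCCc4cccnc42)NC3)CC1`. It keeps the core of compound 2 and carries 4-methylpiperazin-1-yl in place of 3,3-dimethylpiperazin-1-yl on an aromatic carbon.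

For the measured compounds named here, no measured step shows what such a swap does, so the expectation is loose. With compound 2 at 100%, almost no room remains upward, and any real change should be downward. A modest loss is expected, estimated as a number 15 percentage points lower from compound 2 to compound 3 (beyond the scatter), though a result within the usual scatter would not surprise. For compound 3 the estimated value is 85%, with an expected range of 60% to 100%.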

Compound 3, percent of the compound remaining: 75.8%
Compound 3: middle estimate off by 9.2 percentage points, on the high side, within the range that was stated.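

In this assay the group on this aromatic carbon matters: 4-methylpiperazin-1-yl in place of 3,3-dimethylpiperazin-1-yl gives a number 24.2 percentage points lower from compound 2 to compound 3 (beyond the scatter) and so shows that the amount of compound left responds to a change at this position. The swap alters more than one thing at once, with the ring methyl groups gone, a methyl on the ring nitrogen added, and the hydrogen-bond donor count going from 1 to 0, so this single step cannot separate these changes. Nothing at hand explains the step.

As far as these compounds go, it remains open whether the piperazine nitrogens are needed here at all, which a morpholin-4-yl group at the same carbon would test. The compounds shown also leave open how a 3-methylpiperazin-1-yl group, with one ring methyl and the donor kept, would compare with compound 2 and compound 3.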